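Toward compound 4: swapping the group on the chain

The source may report more compounds than this note shows. Statements on the series, on what has been measured and on what is new or still open speak of the compounds shown alone.

Measured in an ADME assay on L929 cells (Mus musculus) for cytotoxicity; on this read-out lower numbers stand for stronger inhibition and higher numbers for weaker inhibition:
- compound 1 `COC(=O)c1cccc(COc2c(-c3ccc(OCCOCCOCCn4cc(CCCCOc5ccc(C=O)cc5)nn4)cc3)oc3ccccc3c2=O)c1`: 37800 nM
- compound 2 `COC(=O)c1cccc(COc2c(-c3ccc(OCCOCCn4cc(CNc5ccccc5)nn4)cc3)oc3ccccc3c2=O)c1`: > 100000 nM (a limit)
- compound 3 `C#CCCCCOc1ccc(-c2oc3ccccc3c(=O)c2OCc2cccc(C(=O)OC)c2)cc1`: > 100000 nM (a limit)

Within the data shown here, compound 1 holds the only true number here, and the rest of the set sits at the limit of > 100000 nM in this assay, at which 2 of the 3 values shown sit. Compound 4 `COC(=O)c1cccc(COc2c(-c3ccc(OCCOCCOCCn4cc(CN(C)Cc5ccccc5)nn4)cc3)oc3ccccc3c2=O)c1` differs from compound 1 by a group of 9 heavy atoms (8 carbon, 1 nitrogen; one six-membered aromatic ring of carbon only) in place of a group of 12 heavy atoms (10 carbon, 2 oxygen; one six-membered aromatic ring of carbon only), on a saturated chain carbon bound to an aromatic carbon: benzyl(methyl)amino enters on a saturated chain carbon bound to an aromatic carbon. Among the measured compounds shown here, no measured step between compounds is available for comparison. The expectation leans on compound 2, whose value is a limit, > 100000 nM. A modest move toward weaker inhibition in this assay is expected, the estimated step being a 1.5-fold higher number from compound 1 to compound 4 (0.16 log units; within the scatter). For compound 4 the expected value is 55000 nM, with an estimated range of 18000 nM to 100000 nM.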

Compound 4, half-maximal inhibitory concentration: > 100000 nM
Compound 4: only a limit was reported; the forecaster's own chance of this, stated with the estimate: 40%; at least 1.8-fold (0.25 log units) between middle value and limit.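

In this assay, benzyl(methyl)amino on the saturated chain carbon bound to an aromatic carbon gives an at least 2.6-fold higher number from compound 1 to compound 4 (0.42 log units; beyond the scatter), the first step readable at this position. Compound 4 gives > 100000 nM, which is a limit, so this step is a lower bound only. Compound 1 remains the only compound in the set with a true number: the limit of > 100000 nM in this assay, at which 3 of the 4 values shown sit.

Which part of the group leaving compound 1 goes with its measurable value stays open. A carboxylic acid or a primary amine on that saturated chain carbon would bear on this.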